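A few compounds are considered here, and "the series" means these few. Any claim that something is new, unique, unknown or untested is made for them only; others in the source may bear on it.

Of the compounds shown here, three of one shared core have been tested in an ADME assay on RAW264.7 cells (Mus musculus) for cytotoxicity, read by MTT assay, with a stated time of 72 h, tested at 100 uM; on this read-out higher numbers stand for a stronger effect at the one concentration tested and lower numbers for a weaker effect. Compound 1 `O=C(Cn1c(=O)oc2ccccc21)NCc1cccs1` gives 49.1%, compound 2 `O=C(Cn1c(=O)oc2cc(Cl)ccc21)Nc1ccccn1` gives 43.7%, and compound 3 `O=C(Cn1c(=O)oc2ccccc21)NCc1ccccn1` gives 38.7%. Compound 3 thus stands lower than compound 1 by a number 10.4 percentage points lower from compound 1 to compound 3 (beyond the scatter), while its number and that of compound 2 lie within the usual scatter of each other. Compound 4 `O=C(Cn1c(=O)oc2ccccc21)Nc1ccccn1` differs from compound 3 in one place: pyridin-2-yl in place of (pyridin-2-yl)methyl on an amide-type nitrogen. Among the measured compounds shown here, no measured step shows this exact change; the only measured step, from compound 1 to compound 3, swaps one ring for another on the chain and is not the same change. Compound 2 carries the same directly attached pyridin-2-yl and its number is near that of compound 3. For compound 4 the expected step is therefore a number 4.3 percentage points higher from compound 3 to compound 4 (within the scatter), which lies within the scatter. Compound 4 is therefore estimated at 43%, between 30% and 56%.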

Compound 4, a percentage reported as inhibition, at one concentration (the size of the read-out at that concentration, not a potency): 28.4%
Compound 4: middle estimate off by 14.6 percentage points, on the high side, and the stated range ends above it.
By their numbers in this assay, from the lowest: compound 4; then compounds 3, 2 and 1 (each within the scatter of the next, the first and the last beyond it).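

In this assay, pyridin-2-yl in place of (pyridin-2-yl)methyl on the amide-type nitrogen gives a number 10.3 percentage points lower from compound 3 to compound 4 (beyond the scatter), so at this position the link to the ring counts, not only the ring itself. With that directly attached ring kept, hydrogen in place of chloro on an aromatic carbon gives a number 15.3 percentage points lower from compound 2 to compound 4 (beyond the scatter), showing that the core also affects the number. Changing both ring and link gives a number 20.7 percentage points lower from compound 1 to compound 4 (beyond the scatter). Nothing available explains these steps. Still open, going by these compounds, is how a longer chain on that nitrogen would behave, and whether chloro would give a similar step with (pyridin-2-yl)methyl in place.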